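Notes on exchanging one hydroxylated phenyl group

This account rests on a few compounds, and the source may have more. Where it says the series, first, only, none or still open, it means among the compounds named here.

Of the compounds shown here, two have numbers so far. In a functional assay on SW480 cells (Homo sapiens) for antiproliferative activity, read by sulforhodamine B assay, with a stated time of 48 h (a lower number here means a stronger inhibitor, a higher number a weaker inhibitor), compound 1 (`COc1ccc(OC)c(/C=C/C(=O)/C=C(O)/C=C/c2cc(OC)ccc2OC)c1`) gives 15600 nM, and compound 2 (`COc1ccc(/C=C/C(=O)C(=Cc2ccc(O)c(F)c2)C(=O)/C=C/c2ccc(OC)cc2OC)c(OC)c1`) gives 3350 nM. Compound 2 therefore holds the lower of the two numbers, and its gap to compound 1 lies beyond the scatter. The two structures differ in more than one place, so this gap says nothing about any single group.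

The next compound is compound 3 (`COc1ccc(/C=C/C(=O)C(=Cc2cc(OC)c(O)c(OC)c2)C(=O)/C=C/c2ccc(OC)cc2OC)c(OC)c1`), which differs from compound 2 in one place: 4-hydroxy-3,5-dimethoxyphenyl in place of 3-fluoro-4-hydroxyphenyl on a double-bonded chain carbon bound to a double-bonded chain carbon. In words, 4-hydroxy-3,5-dimethoxyphenyl stands in place of 3-fluoro-4-hydroxyphenyl on a double-bonded chain carbon bound to a double-bonded chain carbon.

Within the data shown here, no measured pair in this assay tests this exchange, so the only anchor is compound 2 at 3350 nM. A step no larger than the scatter is expected, with a slight lean towards a higher number. The estimated change is a 1.2-fold higher number from compound 2 to compound 3 (0.08 log units; within the scatter). For compound 3 the expected value is 4000 nM, with an estimated range of 1500 nM to 11000 nM.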

Compound 3, half-maximal inhibitory concentration: 850 nM
The estimate for compound 3 lay 4.7-fold (0.67 log units) above the measured number; measured number below the stated range.
By their numbers in this assay, from the lowest: compound 3; then compound 2; then compound 1.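

In this assay the exchange to 4-hydroxy-3,5-dimethoxyphenyl gives a 3.9-fold lower number from compound 2 to compound 3 (0.60 log units; beyond the scatter) and lies beyond the scatter; this first single-place step in the series shows that the group on a double-bonded chain carbon bound to a double-bonded chain carbon does move the number. The entering group is the larger by the counts, with 11 heavy atoms against 8 and 3 hydrogen-bond acceptors against 1 at an unchanged single donor, and here the larger group goes with the lower number, which the gap between compound 1 and compound 2 could not show. Nothing measured on these compounds accounts for the step.

On these data alone, the exchange removes the fluoro group and brings in the dimethoxy pattern in one move, so this single pair cannot separate their shares, and the 4-hydroxy group, present on both sides, remains untested. Also open, as far as these compounds go, is how a phenyl group carrying an amine or a carboxylic acid would behave at this place, and whether the step holds on any other version of the shared core.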